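Swapping cyclohexyl for tert-butyl on the hydroxamate amides

The source may hold more compounds than are shown below. What is called first, only, known or untested is meant among the compounds shown, and "the series" means these compounds.

Measured so far:
compound 1 `CC(C)(C)NC(=O)CN(CCCCCC(=O)NO)C(=O)c1ccccc1`: 20700 nM
compound 2 `O=C(CCCCCN(CC(=O)NC1CCCCC1)C(=O)c1ccccc1)NO`: 3460 nM
compound 3 `CC(C)(C(=O)NC1CCCCC1)N(CCCCCC(=O)NO)C(=O)c1ccccc1`: 295000 nM

The three compounds were tested in a functional assay on A2780 cells (Homo sapiens) for cytotoxicity, read by MTT assay, with a stated time of 72 h; a higher number here means a weaker inhibitor, a lower number a stronger inhibitor. Compound 2 gives 3460 nM and compound 1 gives 20700 nM, so that the move a 6.0-fold higher number from compound 2 to compound 1 (0.78 log units; beyond the scatter) weakens the compound. The change behind that step is tert-butyl in place of cyclohexyl on an amide-type nitrogen. Compound 3 stands apart: in this assay compound 3 gives 295000 nM, which is the highest number of the three, and its steps to both compound 1 and compound 2 lie beyond the scatter. How the core of compound 3 differs from the core of compound 2 is not broken down here.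

Compound 4 `CC(C)(C)NC(=O)C(C)(C)N(CCCCCC(=O)NO)C(=O)c1ccccc1` has not yet been measured in this assay. It arises from compound 3 by tert-butyl in place of cyclohexyl on an amide-type nitrogen. The place is the same as in the step from compound 2 to compound 1, so this is the same change made on a different core. Within the data shown here, the only measured example of it, a 6.0-fold higher number from compound 2 to compound 1 (0.78 log units; beyond the scatter), gives the direction and a rough size, and there is no second example to show whether the core of compound 3 alters it. On that basis compound 4 is expected to be weaker than compound 3 by about a 2.4-fold higher number from compound 3 to compound 4 (0.38 log units; beyond the scatter), with wide uncertainty because the change is shown only once, in a 6.0-fold higher number from compound 2 to compound 1 (0.78 log units; beyond the scatter). Given how high compound 3 already stands, the estimate for compound 4 is 700000 nM, between 200000 nM and 3000000 nM, and a reported limit rather than a number is quite possible.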

Compound 4, half-maximal inhibitory concentration: 207000 nM
Compound 4: middle estimate off by 3.4-fold (0.53 log units), on the high side; the range from low to high includes it.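

In this assay, putting tert-butyl in place of cyclohexyl on the amide-type nitrogen of compound 3 gives a 1.4-fold lower number from compound 3 to compound 4 (0.15 log units; within the scatter), so on this core the change has no effect that can be told from repeat measurement. The change that clearly weakened the compound on the core of compound 2 therefore did not carry over to the core of compound 3 at anything like the same size: the same change on two cores in this assay, a 6.0-fold higher number (0.78 log units; beyond the scatter) from compound 2 to compound 1 and a 1.4-fold lower number (0.15 log units; within the scatter) from compound 3 to compound 4, 8.5-fold (0.93 log units) apart, beyond the scatter of two such steps This shows that the effect of the swap depends on the core it is made on, but it does not show which feature of the core of compound 3 is responsible, and two cores give no rule for predicting the step on a third.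

The compounds shown leave open how other groups on the same amide-type nitrogen, such as n-butyl or phenyl, would behave on each of the two cores, and whether they would separate the cores as cyclohexyl and tert-butyl do. They also leave open whether the same dependence on the core would hold with a longer chain leading to the hydroxamic acid.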